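Adding a Second Fluorine to the Sulfonamide Aryl Group

The source may report more compounds than this note shows. Statements on the series, on what has been measured and on what is new or still open speak of the compounds shown alone.

Measured so far:
compound 1, `O=C(NCc1ccc(CNS(=O)(=O)c2cccc(C(F)(F)F)c2)cc1)c1ccc(F)cc1`, 100 nM;
compound 2, `O=C(NCc1ccc(CNS(=O)(=O)c2cccnc2)cc1)c1ccc(F)cc1`, 1000 nM;
compound 3, `O=C(NCc1ccc(CNS(=O)(=O)c2ccc(F)cc2)cc1)c1ccc(F)cc1`, 1 nM.

In an assay on MDA-MB-231 cells for binding affinity to C-X-C chemokine receptor type 4 (Homo sapiens), read by fluorescence and microscopy, with stated times of 10 min and 30 min (a higher number here means that more compound is needed for the effect, a lower number that less compound is needed), compound 3 gives the lowest number of the three. The step of a 100-fold lower number from compound 1 to compound 3 (2.00 log units; beyond the scatter) and the step of a 1000-fold lower number from compound 2 to compound 3 (3.00 log units; beyond the scatter) both point the same way, and a 10-fold higher number from compound 1 to compound 2 (1.00 log units; beyond the scatter) is smaller.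

Compound 4, `O=C(NCc1ccc(CNS(=O)(=O)c2ccc(F)c(F)c2)cc1)c1ccc(F)cc1`, is unmeasured. It differs from compound 3 by fluoro in place of hydrogen on an aromatic carbon, on the same aryl group attached to the sulfonyl sulfur where the earlier changes sat.

For the measured compounds named here, no measured step adds a single fluoro to a ring that already carries one, so no direct guide exists. The expected step of a 3.0-fold higher number from compound 3 to compound 4 (0.48 log units; beyond the scatter) is therefore small, likely within the scatter. Compound 4 is estimated at 3 nM, between 0.5 nM and 20 nM.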

Compound 4, effective concentration (reported as EC, without a stated level of effect): 10 nM
Compound 4: the middle estimate sits 3.3-fold (0.52 log units) below what was measured; measured number inside the range.
By their numbers in this assay, from the lowest: compound 3; then compound 4; then compound 1; then compound 2.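

In this assay, the second fluorine is not neutral: fluoro in place of hydrogen on the 4-fluorophenyl ring gives a clear loss (a 10-fold higher number from compound 3 to compound 4 (1.00 log units; beyond the scatter)). The 3,4-difluorophenyl group still keeps much of the gain over the other two aryl groups (a 100-fold lower number from compound 2 to compound 4 (2.00 log units; beyond the scatter); a 10-fold lower number from compound 1 to compound 4 (1.00 log units; beyond the scatter)). Nothing measured here explains the size of these steps.

Going by these compounds, it remains open whether a chlorine or a methoxy group, ortho to the fluoro group, would give a lower or higher number than the added fluoro.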